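A few compounds are considered here, and "the series" means these few. Any claim that something is new, unique, unknown or untested is made for them only; others in the source may bear on it.

compound 1 `CC(C)N1C(=O)C(Cc2ccc(F)cc2)COC12C=CC(=O)C=C2`: > 20000 nM
compound 2 `CC(C)N1C(=O)C(Cc2ccc(C(F)(F)F)cc2)COC12C=CC(=O)C=C2`: > 20000 nM

In an assay on isolated protein for inhibition of N-lysine methyltransferase SMYD2 (Homo sapiens), read by filter binding, with a stated time of 1 h (a lower number here means a stronger inhibitor, a higher number a weaker inhibitor), compound 1 gives > 20000 nM, which is a limit of the assay and not a number. Compound 2 gives > 20000 nM, again a limit rather than a number. The step that the two limits leave unreadable from compound 1 to compound 2 therefore cannot be read, since both values sit at the same limit (the limit of > 20000 nM in this assay, at which 2 of the 2 values shown sit). Compound 2 thus stands at that limit, with no number of its own in this assay.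

Compound 3 `CC(C)N1C(=O)C(Cc2ccc(C#N)cc2)COC12C=CC(=O)C=C2` has not yet been measured in this assay. It differs from compound 2 in one place: cyano in place of trifluoromethyl on an aromatic carbon. Going by the values given here, the only measured step, from compound 1 to compound 2, is unreadable, so no measured guide exists for how a change of this group shifts inhibition here. With both known values at the limit, the step that the limit leaves unreadable from compound 2 to compound 3 is expected to show no readable change. Compound 3 is accordingly estimated at 30000 nM, within 10000 nM to 100000 nM, most likely again reported as a limit.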

Compound 3, half-maximal inhibitory concentration: > 20000 nM
Compound 3: no number, only a limit (the forecaster's own chance of this, stated with the estimate: 85%); the middle value is on the limit's open side.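

Compound 3 gives > 20000 nM in this assay, which is a limit of the assay and not a number, so the steps among compound 1, compound 2 and compound 3 cannot be read: the limit of > 20000 nM in this assay, at which 3 of the 3 values shown sit.

The compounds shown leave open whether fluoro, trifluoromethyl and cyano differ at all in their effect on inhibition.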